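This account rests on a few compounds, and the source may have more. Where it says the series, first, only, none or still open, it means among the compounds named here.

Compound 1, `CCCCOC(=O)Cc1c(C(C)C)nc(CCCC)n(Cc2ccc(-c3ccccc3-c3noc(=O)[nH]3)cc2)c1=O`: 21.6%
Compound 2, `CCCCCOC(=O)Cc1c(C(C)C)nc(CCCC)n(Cc2ccc(-c3ccccc3-c3noc(=O)[nH]3)cc2)c1=O`: 19.7%

Both numbers come from an ADME assay on microsomes from liver (Mus musculus) for metabolic stability, with a stated time of 30 min; a higher number here means that more of the compound is left, a lower number that less of the compound is left. Within the data shown here, compound 1 gives 21.6% and compound 2 gives 19.7%; the only step recorded, a number 1.9 percentage points lower from compound 1 to compound 2 (within the scatter), is within the scatter, so these two compounds cannot be told apart on this reading, and compound 1 simply shares the top of a two-member set.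

Compound 3, `CC#CCOC(=O)Cc1c(C(C)C)nc(CCCC)n(Cc2ccc(-c3ccccc3-c3noc(=O)[nH]3)cc2)c1=O`, differs from compound 1 in one place: prop-1-yn-1-yl in place of propyl on a saturated chain carbon bound to an oxygen next to a carbonyl group. Among the measured compounds shown here, the one measured step lengthens the ester chain by a methyl four bonds along the chain from the oxygen; it does not exchange a propyl for a prop-1-yn-1-yl, so no measured step bears directly on this change. What the data do show is that altering this ester chain once, from compound 1 to compound 2, moved this assay only within the scatter. On that basis compound 3 is expected to show no step beyond the scatter, a number 0.4 percentage points higher from compound 1 to compound 3 (within the scatter). The estimate for compound 3 in this assay is 22%, with a range from 10% to 38%.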

Compound 3, percent of the compound remaining: 16.4%
Estimate against measurement, compound 3: 5.6 percentage points above; the measured number falls inside the stated range.
By their numbers in this assay, from the lowest: compounds 3, 2 and 1 (each within the scatter of the next).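

In this assay, putting prop-1-yn-1-yl in place of propyl, which brings a triple bond into the ester chain without altering its count of heavy atoms, gives a number 5.2 percentage points lower from compound 1 to compound 3 (within the scatter), and prop-1-yn-1-yl in place of butyl gives a number 3.3 percentage points lower from compound 2 to compound 3 (within the scatter). The earlier pair showed only a chain made longer by a methyl, whereas this result shows that a change of another kind, on a saturated chain carbon bound to an oxygen next to a carbonyl group, also leaves the three compounds impossible to tell apart on this reading. Nothing measured here offers an explanation for these numbers.

On these data alone, all three compounds carry a chain of carbon atoms alone at this position, so it remains open whether a chain ending in an amine, a carboxylic acid or a phenyl ring would give a step beyond the scatter. It also remains open whether an amide in place of the ester would do so, since every compound shown keeps the ester.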